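The compounds below may be only part of what the source reports. "The series", "measured", "known", "first", "only" and "open" are said of these compounds alone.

Measured so far:
compound 1 `CC1CCN(c2nc(-c3ccc(F)cc3)ccc2CNC(=O)C(C)c2ccc(NS(C)(=O)=O)c(F)c2)CC1` gives 59 nM in an assay on CHO cells for antagonist activity at transient receptor potential cation channel subfamily V member 1 (Homo sapiens), read by FLIPR; on this read-out lower numbers stand for stronger inhibition and higher numbers for weaker inhibition
compound 2 `CC(C(=O)NCc1ccc(C(F)(F)Cl)nc1N1CCCCC1)c1ccc(NS(C)(=O)=O)c(F)c1` gives 1.3 nM in this assay

Compound 2 holds the lowest number of the two, and its gap to compound 1 lies well beyond the scatter. Compound 3 `CC(C)COc1nc(C(F)(F)Cl)ccc1CNC(=O)C(C)c1ccc(NS(C)(=O)=O)c(F)c1` has not yet been measured. It differs from compound 2 in one place: isobutoxy in place of piperidin-1-yl on an aromatic carbon. Among the measured compounds shown here, no measured pair shows this exchange, so its effect must be guessed. A modest rise, slightly beyond the scatter, is expected, giving a 2.3-fold higher number from compound 2 to compound 3 (0.36 log units; beyond the scatter). Compound 3 is therefore estimated at 3 nM, within a range from 0.8 nM to 15 nM.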

Compound 3, inhibition constant: 0.6 nM
For compound 3 the middle estimate is 5.0-fold (0.70 log units) above the measured one; measured number outside the range, below it.
By their numbers in this assay, from the lowest: compound 3; then compound 2; then compound 1.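

At this position, next to the ring nitrogen, a ring is not required for a low number: replacing piperidin-1-yl with the open isobutoxy chain gives a 2.2-fold lower number from compound 2 to compound 3 (0.34 log units; beyond the scatter) in this assay. The position therefore accepts a group joined through oxygen as well as one joined through nitrogen, at least alongside the chloro(difluoro)methyl group. The data at hand do not show why the number falls. From the compounds shown here alone, whether a methoxy group, an unbranched butoxy chain or an open-chain amine would do as well remains open.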